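A few compounds are considered here, and "the series" means these few. Any claim that something is new, unique, unknown or untested is made for them only; others in the source may bear on it.

Measured: compound 1 `COc1cc(C)cc(-c2c(-c3ccnc(-c4ccc(C(C)=O)cc4)c3)cnn2CC#N)c1`, > 100000 nM; compound 2 `COc1cc(C)cc(-c2nn(CC#N)cc2-c2ccc(-c3cccc(C(C)=O)c3)nc2)c1`, 10400 nM.

In a functional assay on IGROV-1 cells (Homo sapiens) for inhibition, read by sulforhodamine B assay, with a stated time of 48 h (a higher number here means a weaker inhibitor of growth, a lower number a stronger inhibitor of growth), compound 1 gives only a limit, > 100000 nM, not a number. Compound 2 gives 10400 nM in this assay. Compound 1 thus stands at the limit of > 100000 nM in this assay, at which 1 of the 2 values shown sits, and cannot be placed on the scale. Compound 3 `COc1cc(C)cc(-c2c(-c3ccnc(-c4ccc(N(C)C)cc4)c3)cnn2CC#N)c1` is not yet measured; it differs from compound 1 by dimethylamino in place of acetyl on an aromatic carbon. For the measured compounds named here, no single-point step between measured compounds is at hand, so the size and direction of the step in this assay are open; with compound 1 at a limit, a further limit is the likelier outcome. Compound 3 is expected at 60000 nM, within 8000 nM to 300000 nM, the estimated step being an at least 1.6-fold lower number from compound 1 to compound 3 (0.22 log units; that floor lies within the scatter).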

Compound 3, concentration for total growth inhibition: 40900 nM
The estimate for compound 3 lay 1.5-fold (0.17 log units) above the measured number; the range from low to high includes it.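

In this assay, the change from 4-acetylphenyl to 4-(dimethylamino)phenyl gives a readable step at this position, para to a large group: an at least 2.4-fold lower number from compound 1 to compound 3 (0.38 log units; beyond the scatter). On the core of compound 1, dimethylamino in place of acetyl therefore replaces a limit with a number. The full size of the step stays unknown, because compound 1 gives a limit and not a number: the limit of > 100000 nM in this assay, at which 1 of the 3 values shown sits.

The compounds shown do not separate the loss of acetyl from the entry of dimethylamino. As far as these compounds go, how a primary amine, a morpholine or a carboxylic acid would read at this place remains open.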